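A few compounds are considered here, and "the series" means these few. Any claim that something is new, unique, unknown or untested is made for them only; others in the source may bear on it.

Measured compounds:
- compound 1, `O=C(NC(=S)Nc1ccc(F)cc1)c1cn(-c2ccccc2)nc1-c1ccc(F)cc1`: 3540 nM
- compound 2, `COc1ccc(NC(=S)NC(=O)c2cn(-c3ccccc3)nc2-c2ccc(OC)cc2)cc1`: 750 nM
- compound 3, `Cc1ccc(NC(=S)NC(=O)c2cn(-c3ccccc3)nc2-c2ccc(Cl)cc2)cc1`: 2690 nM

All three numbers come from a functional assay on A549 cells (Homo sapiens) for inhibition, read by CCK-8 assay, with a stated time of 48 h; a higher number here means a weaker inhibitor, a lower number a stronger inhibitor. Compound 1 gives the highest number of the three. Its gap to compound 3 lies within the scatter, so the two cannot be ordered on these data; its gap to compound 2 lies beyond the scatter, so compound 2 shows the stronger inhibition of that pair. No two of the measured compounds differ in one place only, so no measured step can be read from them.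

The next compound is compound 4, `O=C(NC(=S)Nc1ccc(F)cc1)c1cn(-c2ccccc2)nc1-c1ccccc1`. It differs from compound 1 in one place: hydrogen in place of fluoro on an aromatic carbon. Within the data shown here, no step of this kind has been measured in this assay, and the three measured compounds each carry several changes at once, so the size of the step must be guessed. The expectation is a step of no more than the scatter in this assay, with no clear direction; if anything a slightly higher number.

Compound 4 is expected to give about 4200 nM in this assay, with a range from 1600 nM to 11000 nM. The step of a 1.2-fold higher number from compound 1 to compound 4 (0.07 log units; within the scatter) is thus expected to stay within the scatter.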

Compound 4, half-maximal inhibitory concentration: 3500 nM
Compound 4: middle estimate off by 1.2-fold (0.08 log units), on the high side, within the range that was stated.
By their numbers in this assay, from the lowest: compound 2; then compounds 3, 4 and 1 (each within the scatter of the next).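

In this assay, among these compounds, the change from 4-fluorophenyl to phenyl gives the first measured step that differs in one place only, a 1.0-fold lower number from compound 1 to compound 4 (0.00 log units; within the scatter) and this step lies within the scatter. Among the compounds shown here, at this aromatic carbon, para to a large group, fluoro and hydrogen therefore cannot be told apart, something the earlier compounds, each differing in several places at once, could not show. No measurement at hand bears on the reason for this result.

Still open is what other groups do at this carbon: compound 2 carries methoxy and compound 3 carries chloro on the corresponding ring, but each also differs elsewhere, so no step for either group can be read from the compounds shown. For the compounds shown here, also open is whether a group of another kind at this carbon, such as an amine or a carboxylic acid, would give a step beyond the scatter, or whether this position stays as flat as the single pair of fluoro and hydrogen suggests.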